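The source may report more compounds than this note shows. Statements on the series, on what has been measured and on what is new or still open speak of the compounds shown alone.

Among the compounds with values here, in a functional assay on the whole organism with Rattus norvegicus as the target (on this read-out lower numbers stand for an effect already at smaller amounts and higher numbers for an effect only at larger amounts of compound), three compounds with a shared core have numbers so far. Compound 1 `CCN(CCNC(=O)c1cc(Cl)c(N)cc1OC)Cc1ccoc1` gives 3 mg/kg and compound 3 `COc1cc(N)c(Cl)cc1C(=O)NCCN(C)CC1CCCCC1` gives 3 mg/kg on this scale, while compound 2 `CCN(CCNC(=O)c1cc(Cl)c(N)cc1OC)Cc1ccccn1` gives 30 mg/kg and so stands highest of the three, with a larger dose needed for the same effect. Compound 4 `CCN(CCNC(=O)c1cc(Cl)c(N)cc1OC)Cc1ccccc1OC` differs from compound 2 in one place: 2-methoxyphenyl in place of pyridin-2-yl on a saturated chain carbon bound to an amine nitrogen describes the swap, 2-methoxyphenyl in place of pyridin-2-yl on a saturated chain carbon bound to an amine nitrogen. Within the data shown here, only one measured step touches this same place, namely a 10-fold higher number from compound 1 to compound 2 (1.00 log units; beyond the scatter) when pyridin-2-yl replaced furan-3-yl. Compound 3 also lacks pyridin-2-yl, but it differs in more than that group, so it is weaker evidence. Among the measured compounds shown here, with pyridin-2-yl gone again, a return towards lower numbers seems likely, though no measured compound carries 2-methoxyphenyl and the step may be smaller than that one. The expected change is a 5.0-fold lower number from compound 2 to compound 4 (0.70 log units; beyond the scatter) as an estimate for now. Compound 4 is expected near 6 mg/kg with an estimated range from 1.5 mg/kg to 25 mg/kg on this read-out.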

Compound 4, dose for half-maximal effect: 10 mg/kg
Compound 4: the middle estimate sits 1.7-fold (0.22 log units) below what was measured; low and high end bracket the measured number.
By their numbers in this assay, from the lowest: compounds 1 and 3 (each within the scatter of the next); then compound 4; then compound 2.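

In this assay, swapping pyridin-2-yl for 2-methoxyphenyl on a saturated chain carbon bound to an amine nitrogen gives a 3.0-fold lower number from compound 2 to compound 4 (0.48 log units; beyond the scatter) and so recovers part of the earlier rise, while the change from furan-3-yl to 2-methoxyphenyl gives a 3.3-fold higher number from compound 1 to compound 4 (0.52 log units; beyond the scatter) and shows that the recovery is incomplete. This position now separates three groups, with 2-methoxyphenyl falling between furan-3-yl and pyridin-2-yl, and the two groups with a six-membered aromatic ring do not match, so having that ring type here does not alone fix the number. Nothing shown gives a measured reason for these differences.

This swap removes the ring nitrogen and adds the methoxy group together, and the compounds shown do not separate those two changes. A plain phenyl group at this place would tell them apart.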